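Extending the ether chain with a sulfone terminus

The compounds below may be only part of what the source reports. "The series", "measured", "known", "first", "only" and "open" are said of these compounds alone.

Compound 3 `COCCOc1cc(C)c(-c2cccc(COc3ccc(S(=O)(=O)CC(=O)O)cc3)c2)c(C)c1` holds the highest number of the three compounds measured in a functional assay on CHO cells for agonist activity at Free fatty acid receptor 1 (Homo sapiens), read by FLIPR and calcium flux; on this read-out higher numbers stand for an effect only at larger amounts of compound and lower numbers for an effect already at smaller amounts: compound 3 gives 126 nM, while compound 1 `COc1cc(C)c(-c2cccc(COc3ccc(S(=O)(=O)CC(=O)O)cc3)c2)c(C)c1` gives 57.5 nM and compound 2 `CCCOc1cc(C)c(-c2cccc(COc3ccc(S(=O)(=O)CC(=O)O)cc3)c2)c(C)c1` gives 69.2 nM. The steps run a 2.2-fold higher number from compound 1 to compound 3 (0.34 log units; beyond the scatter) and a 1.8-fold higher number from compound 2 to compound 3 (0.26 log units; within the scatter), so compound 3 is set apart from compound 1 beyond the scatter but not from compound 2.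

Compound 4 `Cc1cc(OCCCS(C)(=O)=O)cc(C)c1-c1cccc(COc2ccc(S(=O)(=O)CC(=O)O)cc2)c1` differs from compound 3 by (methylsulfonyl)methyl in place of methoxy on a saturated chain carbon, two bonds along the chain from an oxygen on an aromatic ring. The step that bears most directly on this place is a 1.8-fold higher number from compound 2 to compound 3 (0.26 log units; within the scatter), which raised the number only within the scatter; the step of a 2.2-fold higher number from compound 1 to compound 3 (0.34 log units; beyond the scatter), growing the same chain, was modest. For the measured compounds named here, no measured step replaces an ether oxygen at this place with a sulfonyl group, and the new chain is longer than any measured here. In this assay compound 4 is therefore expected to give a number somewhat higher than compound 3, with wide uncertainty, an expected step of a 1.4-fold higher number from compound 3 to compound 4 (0.15 log units; within the scatter). Compound 4 is estimated at 180 nM, with a range of 60 nM to 550 nM.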

Compound 4, half-maximal effective concentration in the Free fatty acid receptor 1 assay: 170 nM
Compound 4: middle estimate off by 1.1-fold (0.02 log units), on the high side, and the stated range covers the measured number.
By their numbers in the Free fatty acid receptor 1 assay, from the lowest: compounds 1, 2, 3 and 4 (each within the scatter of the next, the first and the last beyond it).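

In the Free fatty acid receptor 1 assay compound 3 gives 126 nM and compound 4 gives 170 nM, and the step of a 1.3-fold higher number from compound 3 to compound 4 (0.13 log units; within the scatter) shows that 3-(methylsulfonyl)propoxy can stand in place of 2-methoxyethoxy without a change that can be told from the scatter, so this position accepts a sulfonyl-ended chain as well as an ether-ended one. Only against the shorter ethers does the new chain separate, with a 2.5-fold higher number from compound 2 to compound 4 (0.39 log units; beyond the scatter) and a 3.0-fold higher number from compound 1 to compound 4 (0.47 log units; beyond the scatter) both modest and beyond the scatter, which extends the drift seen on growing the chain from compound 1 to compound 3. In a physicochemical assay for lipophilicity, using the shake flask method, in phosphate buffer, measured as octanol-water partition, with a stated time of 24 h, at pH 7.4, tested at 100 uM (a lower number here means a more polar compound, a higher number a more lipophilic compound), compound 3 is recorded as "not determined" (no result reported) and compound 4 as "not determined" (no result reported), so no comparison can be read there. No evidence is at hand to explain these differences.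

Going by these compounds, whether chain length or the terminal group drives that drift stays open, since length and terminus change together in compound 4. A shorter chain ending in methylsulfonyl, or a chain of this length ending in an amine or a carboxylic acid, would bear on that question.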